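The compounds below may be only part of what the source reports. "The series", "measured", "known", "first", "only" and "open" are said of these compounds alone.

Measured so far:
compound 1 `O=C(c1ccccc1)N1CCCn2nc(COc3ccccc3)cc21` — 63%
compound 2 `O=C(c1ccc(F)cc1)N1CCCn2nc(COc3ccccc3)cc21` — 63%
compound 3 `O=C(c1ccncc1)N1CCCn2nc(COc3ccccc3)cc21` — 51%

In a functional assay on HEK293 cells for positive allosteric modulation of metabotropic glutamate receptor 5 (Homo sapiens), read by calcium flux (a lower number here means a smaller maximal response, a higher number a larger maximal response), compound 3 gives 51%, the lowest of the three numbers. The steps of a number 12 percentage points lower from compound 1 to compound 3 (beyond the scatter) and a number 12 percentage points lower from compound 2 to compound 3 (beyond the scatter) both lower the maximal response by a modest amount, whereas no change at the digits printed from compound 1 to compound 2 (within the scatter) stays within the scatter. So far the only change that moved the read-out is the exchange of the aromatic group on the carbonyl carbon.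

Compound 4 `O=C(c1ccno1)N1CCCn2nc(COc3ccccc3)cc21` differs from compound 3 at that same place: 1,2-oxazol-5-yl in place of pyridin-4-yl on a carbonyl carbon. Going by the values given here, no measured step covers a five-membered ring at the carbonyl carbon; the steps that bear on this position, a number 12 percentage points lower from compound 1 to compound 3 (beyond the scatter) and a number 12 percentage points lower from compound 2 to compound 3 (beyond the scatter), were modest. A step of modest size or none beyond the scatter is therefore expected, with the direction uncertain and a slight lowering judged somewhat more likely given that compound 3 already stands at 51%. For compound 4 the expected step is a number 3 percentage points lower from compound 3 to compound 4 (within the scatter). Compound 4 is estimated at 48%, within a range of 33% to 63%.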

Compound 4, largest response reached (reported as percent of maximum), in percent of the reference or control that the assay uses: 22%
Beside the measured number, compound 4's estimate is 26 percentage points above it; the whole stated range lies above it.
By their numbers in this assay, from the lowest: compound 4; then compound 3; then compounds 1 and 2 (each within the scatter of the next).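

In this assay, going by these compounds alone, the carbonyl carbon proves more sensitive to the attached aromatic ring than the earlier compounds showed: replacing pyridin-4-yl with 1,2-oxazol-5-yl gives a number 29 percentage points lower from compound 3 to compound 4 (beyond the scatter), a larger step than any among compounds 1, 2 and 3. Measured against the two carbocyclic aromatic groups, the same five-membered ring gives a number 41 percentage points lower from compound 2 to compound 4 (beyond the scatter) and a number 41 percentage points lower from compound 1 to compound 4 (beyond the scatter), so the maximal response at this position spans far more than the pyridin-4-yl result alone indicated. No evidence is available on the origin of this loss.

The compounds shown leave open whether the drop follows the five-membered ring or its two hetero atoms. A furan-2-yl, thiophen-2-yl or 1,2-oxazol-3-yl group on the same carbonyl carbon would help separate these possibilities.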